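Hydrazone Swap on a Shared Nucleoside Core

The source may hold more compounds than are shown below. What is called first, only, known or untested is meant among the compounds shown, and "the series" means these compounds.

Compound 2 `CSCC/C=N/Nc1nc(N)c2ncn([C@@H]3O[C@H](CO)[C@@H](O)[C@H]3O)c2n1` was tested in an assay on CHO-K1 cells for displacement of a labelled ligand from adenosine receptor A1 (Homo sapiens), read by scintillation counting, with a stated time of 60 min; a lower number here means a stronger inhibitor, a higher number a weaker inhibitor. In this assay compound 2 gives > 10000 nM, which is a limit of the assay and not a number. Compound 1 `CC(=O)Nc1ccc(/C=N/Nc2nc(N)c3ncn([C@@H]4O[C@H](CO)[C@@H](O)[C@H]4O)c3n2)cc1` was tested too; in this assay compound 1 gives > 10000 nM, also a limit. The step that the two limits leave unreadable from compound 1 to compound 2 stays unreadable, given (the limit of > 10000 nM in this assay, at which 2 of the 2 values shown sit). Compound 3 `Nc1nc(N/N=C/c2cccnc2Cl)nc2c1ncn2[C@@H]1O[C@H](CO)[C@@H](O)[C@H]1O` carries 2-chloropyridin-3-yl in place of 2-(methylsulfanyl)ethyl on a carbon with a double bond to nitrogen. Within the data shown here, no measured step of readable size bears on this change, so the expectation rests on the two limits alone. Compound 3 is therefore expected to give 15000 nM, between 3000 nM and 60000 nM. The expected step is a step that the limit leaves unreadable from compound 2 to compound 3.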

Compound 3, inhibition constant: 4.6 nM
Beside the measured number, compound 3's estimate is 3300-fold (3.51 log units) above it; measured number below the stated range.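

In this assay, 2-chloropyridin-3-yl on the carbon with a double bond to nitrogen gives an at least 2100-fold lower number from compound 2 to compound 3 (3.33 log units; beyond the scatter) and an at least 2100-fold lower number from compound 1 to compound 3 (3.33 log units; beyond the scatter). This position can therefore carry a readable value, which neither earlier compound gave. An aromatic ring alone does not account for this, as compound 1 also carries one in its 4-acetamidophenyl group, yet its value is a limit.

From the compounds shown here alone, the step from compound 1 to compound 2 cannot be read: the limit of > 10000 nM in this assay, at which 2 of the 3 values shown sit. Whether the chlorine or the ring nitrogen of 2-chloropyridin-3-yl matters stays open, as does how plain phenyl or 2-chlorophenyl would read.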